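The source may hold more compounds than are shown below. What is called first, only, known or untested is meant among the compounds shown, and "the series" means these compounds.

Measured so far in a functional assay on PC-3 cells (Homo sapiens) for cytotoxicity, read by MTT assay, with a stated time of 72 h; on this read-out higher numbers stand for weaker inhibition and lower numbers for stronger inhibition:
Compound 1 `COc1ccc(Nc2nc3ccccc3nc2S(=O)(=O)c2ccccc2)cc1` — 1510 nM
Compound 2 `Nc1ccc(Nc2nc3ccccc3nc2S(=O)(=O)c2ccccc2)cc1` — 5830 nM

Compound 2 gives the highest of the two numbers in this assay; its nearest neighbour is compound 1, reached by the step of a 3.9-fold higher number from compound 1 to compound 2 (0.59 log units; beyond the scatter), which is beyond the scatter. Compound 3 `O=S(=O)(c1ccccc1)c1nc2ccccc2nc1Nc1ccc(F)cc1` is not yet measured. Its change from compound 2 is fluoro in place of amino on an aromatic carbon. Going by the values given here, no measured step places a fluoro at this position, so the one step that bears on it is the amino-for-methoxy exchange above: it raised the number modestly, and undoing the amino is the part of compound 3's change that the data speak to. From the compounds shown here alone, the expectation is therefore a number lower than compound 2, of a size about like that step, with wide uncertainty because the fluoro itself is untested. The step is estimated as a 2.9-fold lower number from compound 2 to compound 3 (0.46 log units; beyond the scatter). Compound 3 is expected at 2000 nM, within 800 nM to 5000 nM.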

Compound 3, half-maximal inhibitory concentration: 14200 nM
For compound 3 the middle estimate is 7.1-fold (0.85 log units) below the measured one, outside the stated range (above it).
By their numbers in this assay, from the lowest: compound 1; then compound 2; then compound 3.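

In this assay, replacing amino with fluoro gives a 2.4-fold higher number from compound 2 to compound 3 (0.39 log units; beyond the scatter) and so does not recover the ground lost in the amino-for-methoxy exchange. Fluoro in place of methoxy gives a 9.4-fold higher number from compound 1 to compound 3 (0.97 log units; beyond the scatter) and, with all steps beyond the scatter, the order at this position on the ring is methoxy strongest, then amino, then fluoro, so amino is not the least favourable of these three groups. Nothing at hand explains this order.

From the compounds shown here alone, it remains open where a hydroxyl, a chlorine or a plain hydrogen at the same place would fall relative to these three groups. Going by these compounds, it is also open whether the same order would hold with a methyl or a longer alkoxy chain in this place, or with a substituent on the phenyl of the sulfonyl group.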